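Trading a Chlorinated Ring for a Simpler One

The source may hold more compounds than are shown below. What is called first, only, known or untested is meant among the compounds shown, and "the series" means these compounds.

Going by the values given here, compound 2 `O=S(=O)(NCCCNCc1ccc(Cl)c(C(F)(F)F)c1)c1cc(C(F)(F)F)cc(C(F)(F)F)c1` gives 9600 nM in a functional assay on ASPC1 cells (Homo sapiens) for inhibition, read by MTT assay, with a stated time of 72 h (a higher number here means a weaker inhibitor of growth, a lower number a stronger inhibitor of growth), the lowest of the two numbers measured so far, while compound 1 `O=S(=O)(NCCCNCc1ccccc1Cl)c1cc(C(F)(F)F)cc(C(F)(F)F)c1` gives 13000 nM, and the step of a 1.4-fold lower number from compound 1 to compound 2 (0.13 log units; within the scatter) lies within the scatter. Compound 3 `O=S(=O)(NCCCNCc1ccc(C(F)(F)F)cc1)c1cc(C(F)(F)F)cc(C(F)(F)F)c1` is not yet measured in this assay. It differs from compound 2 as follows: 4-(trifluoromethyl)phenyl in place of 4-chloro-3-(trifluoromethyl)phenyl on a saturated chain carbon bound to an amine nitrogen. Among the compounds with values here, the one measured step bears directly on this change, since it altered the same group on the same chain carbon, and it moved the number only slightly. On that basis compound 3 is expected to shift by a 1.3-fold higher number from compound 2 to compound 3 (0.10 log units; within the scatter), a move that stays within the scatter. Compound 3 is therefore estimated at 12000 nM, with a likely range from 6000 nM to 25000 nM, leaving it near compound 1 and compound 2 rather than clearly apart from either.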

Compound 3, concentration for 50% growth inhibition: 2000 nM
The estimate for compound 3 lay 6.0-fold (0.78 log units) above the measured number, and the stated range ends above it.
By their numbers in this assay, from the lowest: compound 3; then compounds 2 and 1 (each within the scatter of the next).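

In this assay, the aryl group on a saturated chain carbon bound to an amine nitrogen now proves able to move the number beyond the scatter, which the step between the two earlier compounds did not show. Placing 4-(trifluoromethyl)phenyl there gives a 4.8-fold lower number from compound 2 to compound 3 (0.68 log units; beyond the scatter) and, measured against the 2-chlorophenyl group, a 6.5-fold lower number from compound 1 to compound 3 (0.81 log units; beyond the scatter), so compound 3 is the strongest inhibitor of growth of the three. Two things change together in the step from 4-chloro-3-(trifluoromethyl)phenyl, the loss of chlorine and the place of the trifluoromethyl, and the numbers do not separate them. Nothing given here accounts for the difference.

The compounds shown leave open how a 4-chlorophenyl or 3-(trifluoromethyl)phenyl group would compare at this carbon. They also leave open whether a nitrile in place of the trifluoromethyl, or a longer chain, would keep this level of growth inhibition.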